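From isopropyl to cyclohexyl on the outer phenyl ring

This account rests on a few compounds, and the source may have more. Where it says the series, first, only, none or still open, it means among the compounds named here.

Measured in an assay on isolated protein for agonist activity at Free fatty acid receptor 1 (Homo sapiens); on this read-out higher numbers stand for an effect only at larger amounts of compound and lower numbers for an effect already at smaller amounts:
compound 1, `CC#CC(CC(=O)O)c1ccc(OCc2ccc3nc(-c4ccc(C(F)(F)F)cc4)cn3c2)cc1`: 558 nM
compound 2, `CC#CC(CC(=O)O)c1ccc(OCc2ccc3nc(-c4ccc(C(C)C)cc4)cn3c2)cc1`: 528 nM

Compound 2 stands beside compound 1 on these two numbers, and the gap between them lies within the scatter, so the two cannot be told apart. Compound 3, `CC#CC(CC(=O)O)c1ccc(OCc2ccc3nc(-c4ccc(C5CCCCC5)cc4)cn3c2)cc1`, has not yet been measured. It differs from compound 2 by cyclohexyl in place of isopropyl on an aromatic carbon. Within the data shown here, the only measured step, a 1.1-fold lower number from compound 1 to compound 2 (0.02 log units; within the scatter), changed the group at this same position and stayed within the scatter; no measured compound carries a cyclohexyl there. Compound 3 is therefore expected to show a change of a 1.1-fold lower number from compound 2 to compound 3 (0.02 log units; within the scatter), that is none beyond the scatter. The estimate for compound 3 is 500 nM, ranging from 200 nM to 1500 nM.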

Compound 3, half-maximal effective concentration: 417 nM
Estimate against measurement, compound 3: 1.2-fold (0.08 log units) above; the measured number falls inside the stated range.
By their numbers in this assay, from the lowest: compounds 3, 2 and 1 (each within the scatter of the next).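

Cyclohexyl brings a non-aromatic ring and more heavy atoms to this aromatic carbon, yet this assay shows a 1.3-fold lower number from compound 2 to compound 3 (0.10 log units; within the scatter) and a 1.3-fold lower number from compound 1 to compound 3 (0.13 log units; within the scatter), both small steps. So a ring at this position, para to a large group, is accommodated as well as the two smaller groups, and trifluoromethyl, isopropyl and cyclohexyl cannot be told apart here. Nothing available explains why the number stays so flat.

Open, on these data alone, is whether an amine or a hydroxyl on this aromatic carbon would move the number beyond the scatter. As far as these compounds go, a phenyl ring there remains equally open.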